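A few compounds are considered here, and "the series" means these few. Any claim that something is new, unique, unknown or untested is made for them only; others in the source may bear on it.

Measured compounds in an ADME assay on RAW264.7 cells (Mus musculus) for cytotoxicity, read by MTT assay, with a stated time of 48 h; a lower number here means a stronger inhibitor, a higher number a weaker inhibitor:
Compound 1 `COc1cc(NC(=O)c2ccc(Cl)cc2)ccc1NS(=O)(=O)C(F)(F)F` gives 108000 nM.
Compound 2 `COc1cc(NC(=O)c2ccc(C#N)cc2)ccc1NS(=O)(=O)C(F)(F)F` gives only a limit, > 250000 nM.
Compound 3 `COc1cc(NC(=O)c2ccc(Cl)c([N+](=O)[O-])c2)ccc1NS(=O)(=O)C(F)(F)F` gives only a limit, > 250000 nM.

Compound 1 is thus the only one of the three with a real number; the other two sit at the limit of > 250000 nM in this assay, at which 2 of the 3 values shown sit. Compound 4 `O=C(Nc1ccc(NS(=O)(=O)C(F)(F)F)c(F)c1)c1ccc(Cl)cc1` differs from compound 1 by fluoro in place of methoxy on an aromatic carbon. The two measured steps, an at least 2.3-fold higher number from compound 1 to compound 2 (0.36 log units; beyond the scatter) and an at least 2.3-fold higher number from compound 1 to compound 3 (0.36 log units; beyond the scatter), both alter a different part of compound 1, so neither directly tests the exchange of methoxy for fluoro. With no comparable change measured, the step of a 1.1-fold higher number from compound 1 to compound 4 (0.05 log units; within the scatter) is expected to stay within the scatter. Compound 4 is therefore estimated at 120000 nM, with a range from 50000 nM to 250000 nM.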

Compound 4, half-maximal inhibitory concentration: 3270 nM
Compound 4: middle estimate off by 37-fold (1.56 log units), on the high side; the measured number lies below the stated range.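

The place ortho to a ((trifluoromethyl)sulfonyl)amino group matters strongly in this assay: fluoro in place of methoxy there gives a 33-fold lower number from compound 1 to compound 4 (1.52 log units; beyond the scatter). This is the first change shown that moves the number down, towards stronger cytotoxicity, whereas the two earlier changes elsewhere moved it up. It is also the only step with real numbers at both ends, as the others end at a limit: the limit of > 250000 nM in this assay, at which 2 of the 4 values shown sit.

From the compounds shown here alone, whether losing methoxy or gaining fluoro drives the step stays open. Hydrogen, chloro or an ethoxy group at this place could separate the two.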